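Heteroaryl swap on the shared core

The compounds below may be only part of what the source reports. "The series", "measured", "known", "first", "only" and "open" are said of these compounds alone.

Measured so far:
compound 1 `CS(=O)(=O)Nc1cccc2c1CCC2c1ncc[nH]1` — in a functional assay on CHO cells for agonist activity at Alpha-1D adrenergic receptor (Homo sapiens), read by FLIPR and calcium flux (a lower number here means that less compound is needed, a higher number that more compound is needed for the effect), compound 1 gives > 10000 nM, a limit of the assay.
compound 2 `c1cc(-c2ncco2)c2c(c1)C(c1ncc[nH]1)CC2` — in this assay compound 2 gives 1390 nM.

For the measured compounds named here, compound 2 holds the only number in this assay; the other value is a limit (the limit of > 10000 nM in this assay, at which 1 of the 2 values shown sits). Going by the values given here, the single measured step is an at least 7.1-fold lower number from compound 1 to compound 2 (0.85 log units; beyond the scatter), a different change from the one now followed. Compound 3 `Cn1nccc1-c1cccc2c1CCC2c1ncc[nH]1` is unmeasured. The change is 1-methyl-1H-pyrazol-5-yl in place of 1,3-oxazol-2-yl on an aromatic carbon. Among the compounds with values here, no measured step covers exchanging one five-membered aromatic ring with 2 hetero atoms for another, so no step beyond the scatter is expected in this assay. Compound 3 is estimated at 1500 nM, range 400 nM to 6000 nM, an expected step of a 1.1-fold higher number from compound 2 to compound 3 (0.03 log units; within the scatter).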

Compound 3, half-maximal effective concentration: > 10000 nM
Compound 3 ended at the assay's limit; the forecaster's own chance of this, stated with the estimate: 15%; middle value at least 6.6-fold (0.82 log units) away from the limit.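

At this aromatic carbon of the shared core, one five-membered aromatic ring with 2 hetero atoms does not simply stand in for another in this assay: 1-methyl-1H-pyrazol-5-yl in place of 1,3-oxazol-2-yl gives an at least 7.1-fold higher number from compound 2 to compound 3 (0.85 log units; beyond the scatter). The value of compound 3 is a limit of the assay, so the step from compound 1 to compound 3 cannot be read. Only compound 2 gives a number here: the limit of > 10000 nM in this assay, at which 2 of the 3 values shown sit.

Open, going by these compounds, is whether the methyl group of 1-methyl-1H-pyrazol-5-yl or the ring itself carries this step. Also open, on these data alone, is how an amine or a carboxylic acid at this aromatic carbon would read.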